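Adding a Methoxy Group: From Compound 2 to Compound 4

This account rests on a few compounds, and the source may have more. Where it says the series, first, only, none or still open, it means among the compounds named here.

Three compounds have been measured in a functional assay on PC-3 cells (Homo sapiens) for inhibition, read by sulforhodamine B assay, with a stated time of 48 h; a lower number here means a stronger inhibitor of growth, a higher number a weaker inhibitor of growth:

Compound 1, `COc1ccc(-c2cc(/C=C/C(=O)c3ccc(N)cc3)[nH]n2)cc1`, gives 10100 nM.
Compound 2, `COc1ccc(C(=O)/C=C/c2cc(-c3cc(OC)c(OC)c(OC)c3)n[nH]2)cc1OC`, gives 2800 nM.
Compound 3, `COc1ccc(-c2cc(/C=C/C(=O)c3ccc(N)cc3)[nH]n2)cc1OC`, gives 19800 nM.

Compound 3 is made from compound 1 by one change, (methoxy in place of hydrogen on an aromatic carbon), and that change brought a 2.0-fold higher number from compound 1 to compound 3 (0.29 log units; within the scatter). Compound 2 stands with the lowest number of the three, and its steps to compound 1 and to compound 3 are both beyond the scatter; the difference between the core of compound 1 and the core of compound 2 is not broken down here.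

Compound 4, `COc1cc(C(=O)/C=C/c2cc(-c3cc(OC)c(OC)c(OC)c3)n[nH]2)cc(OC)c1OC`, is not yet measured. It is made from compound 2 by methoxy in place of hydrogen on an aromatic carbon. The surroundings are not identical: in compound 4 the place is also meta to a methoxy group, so this is the same kind of change as before, not the same change. From compound 2 to compound 4 a step of a 1.4-fold higher number from compound 2 to compound 4 (0.15 log units; within the scatter) is expected in this assay, because a 2.0-fold higher number from compound 1 to compound 3 (0.29 log units; within the scatter) was small and within the scatter. Compound 4 is therefore estimated at 4000 nM, expected to fall between 1500 nM and 12000 nM.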

Compound 4, concentration for total growth inhibition: 3290 nM
For compound 4 the middle estimate is 1.2-fold (0.08 log units) above the measured one, and the stated range covers the measured number.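

In this assay, methoxy in place of hydrogen on an aromatic carbon brought a 1.2-fold higher number from compound 2 to compound 4 (0.07 log units; within the scatter). Set beside the earlier case of this change, the two steps agree as closely as such measurements can tell: the same change on two cores in this assay, a 2.0-fold higher number (0.29 log units; within the scatter) from compound 1 to compound 3 and a 1.2-fold higher number (0.07 log units; within the scatter) from compound 2 to compound 4, 1.7-fold (0.22 log units) apart, within the scatter of two such steps On these two cores, then, the change carried over with no step beyond the scatter, but two pairs cannot show that it would behave the same way on a third core, and the data do not explain why the steps are small.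

The compounds shown compare only hydrogen with methoxy at these places, so it remains open whether a hydroxyl group, a chlorine atom or a longer chain such as ethoxy would move the number beyond the scatter. Both steps also come from a single assay on one cell line, so whether they would stay this small on other cells is open too.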